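The source may report more compounds than this note shows. Statements on the series, on what has been measured and on what is new or still open speak of the compounds shown alone.

Of the compounds shown here, three built on one shared core have been tested in a functional assay on OVCAR-8 cells (Homo sapiens) for inhibition, read by sulforhodamine B assay, with a stated time of 48 h, tested at 10 uM; on this read-out higher numbers stand for more inhibition at the one concentration tested (going by the name of the read-out) and lower numbers for less inhibition. Compound 1 `c1ccc(-c2cn3ccnc3c(-c3ccc4ncn(C5CCCCC5)c4c3)n2)cc1` gives 63.9% in this assay. Compound 2 `O=Cc1ccc(-c2cn3ccnc3c(-c3ccc4ncn(C5CCCCC5)c4c3)n2)cc1` gives 44%, the second highest of the three numbers: it lies a number 19.9 percentage points lower from compound 1 to compound 2 (beyond the scatter), and compound 3 `CC(=O)c1ccc(-c2cn3ccnc3c(-c3ccc4ncn(C5CCCCC5)c4c3)n2)cc1`, which gives 6.38%, lies a number 37.6 percentage points lower from compound 2 to compound 3 (beyond the scatter). Compound 4 `Brc1ccc(-c2cn3ccnc3c(-c3ccc4ncn(C5CCCCC5)c4c3)n2)cc1` has not yet been measured. It differs from compound 2 by bromo in place of formyl on an aromatic carbon.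

Within the data shown here, no measured step introduces a bromo group, so the expectation rests on the steps around the carbonyl-bearing groups. The modest fall a number 19.9 percentage points lower from compound 1 to compound 2 (beyond the scatter) came with formyl in place of hydrogen on an aromatic carbon, and the large fall a number 37.6 percentage points lower from compound 2 to compound 3 (beyond the scatter) came with methyl in place of hydrogen on a carbonyl carbon. Both groups that carry a carbonyl sit below the unsubstituted compound 1, and removing the formyl group in favour of bromo takes away that carbonyl. A return toward the level of compound 1 therefore seems likely, though bromo is not hydrogen and the size of the return is uncertain. Compound 4 is expected to show an upward step of a number 14 percentage points higher from compound 2 to compound 4 (beyond the scatter) in this assay. The estimate for compound 4 is 58%, with a range from 35% to 78%.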

Compound 4, a percentage reported as inhibition, at one concentration (the size of the read-out at that concentration, not a potency): 13.2%
For compound 4 the middle estimate is 44.8 percentage points above the measured one; the measured number lies below the stated range.
By their numbers in this assay, from the lowest: compounds 3 and 4 (each within the scatter of the next); then compound 2; then compound 1.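

Bromo carries no carbonyl, yet it still gives a number 50.7 percentage points lower from compound 1 to compound 4 (beyond the scatter) when it replaces hydrogen on this carbon of the six-membered aromatic ring of carbon only, para to a large group, so among these compounds a carbonyl is not required for a loss of inhibition at this position. The change from 4-formylphenyl to 4-bromophenyl gives a number 30.8 percentage points lower from compound 2 to compound 4 (beyond the scatter) and bromo in place of acetyl gives a number 6.8 percentage points higher from compound 3 to compound 4 (within the scatter), so bromo and acetyl cannot be told apart here even though the two groups share little in their atoms. Hydrogen in compound 1 therefore remains the best of the four at this position, and none of the three substituted compounds goes against that, with formyl in compound 2 giving up the least of the inhibition.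

Nothing available here explains why these groups rank as they do. From the compounds shown here alone, it remains open whether a fluoro group, an amine or a carboxylic acid on this carbon would keep the level of compound 1 at 63.9% in this assay or fall as far as bromo and acetyl do.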